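From Methyl to 4-Fluorophenyl on the Ring Nitrogen

The source may report more compounds than this note shows. Statements on the series, on what has been measured and on what is new or still open speak of the compounds shown alone.

Compound 1, `COc1cc(-c2nccn2C)cc(OC)c1OC`, was examined in a functional assay on HT-29 cells (Homo sapiens) for antiproliferative activity, read by MTT assay, with a stated time of 72 h; a higher number here means a weaker inhibitor, a lower number a stronger inhibitor. In this assay compound 1 gives only a limit, > 100000 nM. Two related compounds stand at the same place. Compound 2, `COc1cc(-c2nccn2S(=O)(=O)c2ccccc2)cc(OC)c1OC`, gives > 100000 nM in this assay, a limit rather than a number. Compound 3, `COc1cc(-c2nccn2-c2cccc([N+](=O)[O-])c2)cc(OC)c1OC`, gives > 100000 nM, again a limit. Compound 1 therefore does not stand apart from anything: the limit of > 100000 nM in this assay, at which 3 of the 3 values shown sit. Going by the values given here, no pair of measured compounds differs in one place, so no measured step can be followed.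

Compound 4, `COc1cc(-c2nccn2-c2ccc(F)cc2)cc(OC)c1OC`, is the untested member. It differs from compound 1 by 4-fluorophenyl in place of methyl on an aromatic nitrogen. Compound 3 also carries a larger group on that aromatic nitrogen and yet returns a limit, > 100000 nM. Compound 4 is thus expected to remain at the limit as well, and the step that the limit leaves unreadable from compound 1 to compound 4 is expected to be none beyond the scatter. The estimate for compound 4 is 150000 nM, with a range from 30000 nM to 1000000 nM.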

Compound 4, half-maximal inhibitory concentration: 29300 nM
Compound 4: middle estimate off by 5.1-fold (0.71 log units), on the high side; the measured number lies below the stated range.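

In this assay, the aromatic nitrogen proves to be a position where a change can bring a readable value: 4-fluorophenyl in place of methyl gives an at least 3.4-fold lower number from compound 1 to compound 4 (0.53 log units; beyond the scatter). A six-membered aromatic ring on this nitrogen is not enough by itself, since compound 3, whose ring bears a nitro group, gives > 100000 nM, which is a limit. Compound 4 alone among the compounds shown gives a number rather than a limit: the limit of > 100000 nM in this assay, at which 3 of the 4 values shown sit.

From the compounds shown here alone, the full size of the step stays unknown, as does any step among the three compounds held at the limit, and those steps cannot be read. Open too, going by these compounds, is whether the fluorine matters, which a plain phenyl on the same nitrogen would test, and how a benzyl group, a longer chain or an amine-bearing ring would fare there.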